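The compounds below may be only part of what the source reports. "The series", "measured", "known", "first", "only" and "open" are said of these compounds alone.

Three compounds sharing one core were tested in an ADME assay on HeLa cells (Homo sapiens) for cytotoxicity, read by microscopy, with a stated time of 6 days; a lower number here means that less compound is tolerated, a higher number that more compound is tolerated. Compound 1 `COc1cccc(N2C(N)=NC(N)=NC23CCN(C(=O)c2ccc(C(F)(F)F)cc2C)CC3)c1` gives only a limit of the assay, > 100000 nM. Compound 2 `CCCN1C(N)=NC(N)=NC12CCN(C(=O)NCCC(=O)OCC)CC2` likewise returns only a limit, > 100000 nM. Compound 3 `COCCN1C(N)=NC(N)=NC12CCN(C(=O)c1cccn1C)CC2` also stands at a limit, > 100000 nM. For the measured compounds named here, no compound here produced a number; all three rest at the limit of > 100000 nM in this assay, at which 3 of the 3 values shown sit. The unmeasured compound 4 `COCCN1C(N)=NC(N)=NC12CCN(C(=O)Nc1ccc(OC)cc1)CC2` differs from compound 3 in one place: (4-methoxyphenyl)amino in place of 1-methyl-1H-pyrrol-2-yl on a carbonyl carbon. Since every measured value sits at the limit, the expected step is a number no higher from compound 3 to compound 4 (the limit leaves the size open), that is, none beyond the scatter. Compound 4 is therefore estimated at 100000 nM in this assay, with a range from 30000 nM to 100000 nM, most likely reported again as a limit only.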

Compound 4, minimum cytotoxic concentration: > 100000 nM
Compound 4: a limit, no number; the forecaster's own chance of this, stated with the estimate: 85%; the middle value lies on the limit itself.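

Compound 3 and compound 4 each give only a limit, so no step can be read between them: the limit of > 100000 nM in this assay, at which 4 of the 4 values shown sit. The compounds shown leave open what concentration, if any, would produce a measurable number in this assay.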